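The source may hold more compounds than are shown below. What is called first, only, known or untested is meant among the compounds shown, and "the series" means these compounds.

Measured so far in a functional assay on MCF7 cells (Homo sapiens) for cytotoxicity; on this read-out higher numbers stand for weaker inhibition and lower numbers for stronger inhibition:
- compound 1 `CCC(CO)Nc1nc(NCc2cccc(O)c2)c2nc(Cl)n(C(C)C)c2n1`: 27000 nM
- compound 2 `CCC(CO)Nc1nc(NCc2ccccc2)c2nc(O)n(C(C)C)c2n1`: 65000 nM
- compound 3 `CCC(CO)Nc1nc(NCc2ccccc2)c2nc([N+](=O)[O-])n(C(C)C)c2n1`: 117000 nM

Compound 2 stands within the scatter of compound 3, while compound 1 shows a lower number than compound 2. Compound 4 `CCC(CO)Nc1nc(NCc2ccccc2)c2nc(NCCCO)n(C(C)C)c2n1` is the next case, with (3-hydroxypropyl)amino in place of hydroxy on an aromatic carbon. Among the measured compounds shown here, one measured step bears on it, at the same carbon: a 1.8-fold higher number from compound 2 to compound 3 (0.26 log units; within the scatter), which lies within the scatter. That single step is thin evidence, and no amino group has been measured here. No change beyond the scatter is therefore expected in this assay. The expected step is a 1.2-fold lower number from compound 2 to compound 4 (0.07 log units; within the scatter). The estimate for compound 4 is 55000 nM, with an expected range of 20000 nM to 130000 nM.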

Compound 4, half-maximal inhibitory concentration: 40000 nM
For compound 4 the middle estimate is 1.4-fold (0.14 log units) above the measured one, within the range that was stated.
By their numbers in this assay, from the lowest: compounds 1, 4, 2 and 3 (each within the scatter of the next, the first and the last beyond it).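

In this assay this carbon takes (3-hydroxypropyl)amino, 5 heavy atoms against 1 for hydroxy, with a 1.6-fold lower number from compound 2 to compound 4 (0.21 log units; within the scatter) as the result. Against nitro the same group gives a 2.9-fold lower number from compound 3 to compound 4 (0.47 log units; beyond the scatter) and this is the first step at this carbon beyond the scatter, though a modest one. No measurement in hand accounts for either step.

From the compounds shown here alone, whether a plain amine, a shorter or longer chain without the terminal hydroxy, or a carboxylic acid at this carbon would shift the number remains open. Compound 1 differs from the others in more than one place, so its comparison with them cannot be read.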